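Shortening the Side Chain on a Shared Core

The source may report more compounds than this note shows. Statements on the series, on what has been measured and on what is new or still open speak of the compounds shown alone.

Of the compounds shown here, three built on one core have been measured in a physicochemical assay for lipophilicity; a lower number here means a more polar compound, a higher number a more lipophilic compound. Compound 1 `O=c1oc(NC2CCCCC2)nc2ccccc12` gives 3.5 and stands highest of the three. Compound 2 `CCNc1ccc2c(=O)oc(NC(C)C)nc2c1` gives 2.4, a number beyond the scatter below compound 1, and compound 3 `Cc1ccc2nc(C)oc(=O)c2c1` gives 1.8, the furthest below compound 1, again beyond the scatter. No two of these differ in just one place, so no single change has yet been tied to a shift in this assay.

Compound 4 `CCCNc1nc2ccccc2c(=O)o1` has not been measured. It differs from compound 1 in one place: propyl in place of cyclohexyl on a nitrogen on an aromatic ring. The move from compound 1 to compound 4 is expected to lower the number in this assay by a step clearly beyond the scatter, since the value of compound 1 at 3.5 carries the cyclohexyl that is removed, and the expected shift is a number 1.10 log units lower from compound 1 to compound 4 (beyond the scatter). Compound 4 is therefore estimated at 2.4, in a range from 1.9 to 2.9.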

Compound 4, distribution coefficient: 2.4
For compound 4 middle estimate and measured number coincide at the digits printed; the range from low to high includes it.
By their numbers in this assay, from the lowest: compound 3; then compounds 2 and 4 (each within the scatter of the next); then compound 1.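

Among these compounds, this is the first pair on the shared core that differs in one place only, so a shift in this assay can now be tied to a single change: propyl in place of cyclohexyl on a nitrogen on an aromatic ring gives a number 1.10 log units lower from compound 1 to compound 4 (beyond the scatter). The group on this nitrogen therefore matters to the read-out, even though both groups are made of carbon only, with no hydrogen-bond donors or acceptors and no net charge. Nothing available explains why the number moves as it does.

A single pair cannot separate losing the ring from having fewer carbons, since both happen in the same step. Going by these compounds, how a hexyl chain, a cyclopropyl ring or a chain ending in an amine would read on this nitrogen remains open.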